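This account rests on a few compounds, and the source may have more. Where it says the series, first, only, none or still open, it means among the compounds named here.

Measured in a functional assay on SMMC-7721 cells (Homo sapiens) for inhibition, read by CCK-8 assay, with a stated time of 72 h, tested at 2 uM; a higher number here means more inhibition of growth at the concentration tested, a lower number less inhibition of growth:
- compound 1 `Nc1ccccc1NC(=O)c1ccc(CSc2ccc(Br)cc2)cc1`: 10%
- compound 2 `Nc1ccccc1NC(=O)/C=C/c1ccc(CSc2ccc(F)cc2)cc1`: 18.3%
- compound 3 `Nc1ccccc1NC(=O)c1ccc(CSc2cccc(F)c2)cc1`: 18.6%

Compound 2 lies within the scatter of both other values: of compound 3, the nearest, and of compound 1, the furthest. Compound 4 `CC(C)(C)c1ccc(SCc2ccc(/C=C/C(=O)Nc3ccccc3N)cc2)cc1` differs from compound 2 by tert-butyl in place of fluoro on an aromatic carbon. Within the data shown here, the only measured step that bears on a substituent change on the phenyl attached to sulfur is a number 8.6 percentage points higher from compound 1 to compound 3 (within the scatter), and it stays within the scatter. Nothing measured speaks for a step beyond the scatter here, so for compound 4 the expected step is a number 1.7 percentage points higher from compound 2 to compound 4 (within the scatter). The estimate for compound 4 in this assay is 20%, with a range from 5% to 40%.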

Compound 4, percent growth inhibition at one concentration: 18.3%
For compound 4 the middle estimate is 1.7 percentage points above the measured one; low and high end bracket the measured number.
By their numbers in this assay, from the lowest: compounds 1, 2, 4 and 3 (each within the scatter of the next).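

In this assay, 4-(tert-butyl)phenyl in place of 4-fluorophenyl gives no change at the digits printed from compound 2 to compound 4 (within the scatter) on the core of compound 2. Unlike the step between compound 1 and compound 3, which alters both the group and its place on the ring, this change keeps the place fixed and goes from 1 heavy atom to 4 heavy atoms without a shift beyond the scatter. No other measurement bearing on this result is available.

As far as these compounds go, whether an amine, a carboxylic acid or a longer chain at this aromatic carbon would move the read-out beyond the scatter remains open.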